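The source may hold more compounds than are shown below. What is called first, only, known or untested is meant among the compounds shown, and "the series" means these compounds.

Measured compounds:
- compound 1 `O=C(O)COc1cccc(CCCn2cc(C(c3ccccc3)c3ccccc3)ccc2=O)c1` — 5950 ng.h/mL
- compound 2 `COc1ccc(C(=O)N(CCCc2cccc(OCC(=O)O)c2)CCC(c2ccccc2)c2ccccc2)cc1` — 270 ng.h/mL

In an ADME assay on the whole organism (plasma, strain Hartley) for pharmacokinetics, with Cavia porcellus as the target, at a dose of 10 mg/kg by the oral route (a higher number here means more compound in the circulation at the dose given, a lower number less compound in the circulation), compound 1 gives 5950 ng.h/mL, the higher of the two numbers recorded so far. Within the data shown here, compound 2 gives 270 ng.h/mL in this assay, a gap that lies beyond the scatter of repeated measurements; no single-point step connects compound 1 and compound 2, so the pair shows only that exposure can differ widely.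

Compound 3 `O=C(O)CCCOc1cccc(CCCn2cc(C(c3ccccc3)c3ccccc3)ccc2=O)c1` is not yet measured. It differs from compound 1 in one place: 2-carboxyethyl in place of carboxy on a saturated chain carbon bound to an oxygen on an aromatic ring. The core and the rest of compound 1 are kept. Among the measured compounds shown here, no measured pair reports the effect of lengthening this chain, so the direction of the change is unsupported by data.

The step from compound 1 to compound 3 in this assay is expected to be small, a 1.5-fold lower number from compound 1 to compound 3 (0.17 log units; within the scatter), most likely within the scatter and leaning, if anything, toward a lower number. Compound 3 is therefore estimated at 4000 ng.h/mL, with a range from 1200 ng.h/mL to 12000 ng.h/mL.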

Compound 3, area under the concentration-time curve: 1020 ng.h/mL
Estimate against measurement, compound 3: 3.9-fold (0.59 log units) above, outside the stated range (below it).
By their numbers in this assay, from the lowest: compound 2; then compound 3; then compound 1.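

Among these compounds, this is the first single-point change, and in this assay it is not neutral: 2-carboxyethyl in place of carboxy, on a saturated chain carbon bound to an oxygen on an aromatic ring, gives a step beyond the scatter (a 5.8-fold lower number from compound 1 to compound 3 (0.77 log units; beyond the scatter)). With the shared core and the rest of compound 1 kept, exposure at this dose therefore responds to the length of the chain carrying the carboxylic acid, with the carboxymethoxy group of compound 1 giving the higher number and the 3-carboxypropoxy group of compound 3 the lower. No measurement available here bears on the reason for this step.

The compounds shown cover only these two chain lengths, so it remains open whether the number falls steadily with length, whether a 2-carboxyethoxy chain lies between them, and whether a still longer chain lowers it further. Also open, from the compounds shown here alone, are the effect of a methyl group on the saturated chain carbon bound to the oxygen and of an amide in place of the carboxylic acid, and whether the same chain change gives a step of this size on the other scaffold, that of compound 2.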